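A Pyrimidinyl Replaces the Cyanophenyl on the Ring Nitrogen

The compounds below may be only part of what the source reports. "The series", "measured", "known", "first", "only" and "open" are said of these compounds alone.

Three compounds share one core and differ only in the group on an amine nitrogen in a ring. Compound 1 `Nc1ccccc1NC(=O)c1ccc(CSC(=S)N2CCN(c3ccc(Cl)cc3)CC2)cc1` carries chloro on an aromatic carbon, compound 2 `Nc1ccccc1NC(=O)c1ccc(CSC(=S)N2CCN(c3ccc(F)cc3)CC2)cc1` carries fluoro there, and compound 3 `N#Cc1ccc(N2CCN(C(=S)SCc3ccc(C(=O)Nc4ccccc4N)cc3)CC2)cc1` carries cyano. In a functional assay on MGC-803 cells (Homo sapiens) for antiproliferative activity, read by CCK-8 assay, with a stated time of 72 h, tested at 2 uM (a lower number here means a weaker effect, a higher number a stronger effect of the compound at the concentration tested), compound 1 gives 15%, compound 2 gives 18.8% and compound 3 gives 34.5%, the highest of the three. The change a number 3.8 percentage points higher from compound 1 to compound 2 (within the scatter) stays within the scatter, whereas a number 19.5 percentage points higher from compound 1 to compound 3 (beyond the scatter) and a number 15.7 percentage points higher from compound 2 to compound 3 (beyond the scatter) are modest steps beyond it.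

Compound 4 `Nc1ccccc1NC(=O)c1ccc(CSC(=S)N2CCN(c3ncccn3)CC2)cc1` has not been measured. It differs from compound 3 in one place: pyrimidin-2-yl in place of 4-cyanophenyl on an amine nitrogen in a ring. Among the measured compounds shown here, none of the measured steps bears directly on this change, since each of them only exchanged the substituent on an aromatic carbon and kept the same ring; here the ring itself is exchanged. For the measured compounds named here, the two steps toward compound 3 show that its cyano is what sets it apart from compound 1 and compound 2, so removing that group may give back part of that gain, but no measured pair tells how much. Compound 4 is therefore estimated at 22% in this assay, between 8% and 40%, with an expected step of a number 12.5 percentage points lower from compound 3 to compound 4 (beyond the scatter) that remains uncertain.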

Compound 4, a percentage reported as inhibition, at one concentration (the size of the read-out at that concentration, not a potency): 28.4%
Compound 4: the middle estimate sits 6.4 percentage points below what was measured; the measured number falls inside the stated range.
By their numbers in this assay, from the lowest: compounds 1, 2, 4 and 3 (each within the scatter of the next, the first and the last beyond it).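

Among the compounds shown here, exchanging the whole ring on the amine nitrogen, rather than only a substituent on it, was tested here for the first time: in this assay, pyrimidin-2-yl in place of 4-cyanophenyl gives a number 6.1 percentage points lower from compound 3 to compound 4 (within the scatter), so at this position the nitrile and its carbon-only aromatic ring can both be gone without a step beyond the scatter. Set against the halogen-bearing rings, the same pyrimidin-2-yl gives a split result, with a number 9.6 percentage points higher from compound 2 to compound 4 (within the scatter) for the exchange of 4-fluorophenyl and a number 13.4 percentage points higher from compound 1 to compound 4 (beyond the scatter) for the exchange of 4-chlorophenyl, and only the latter of these two lies beyond the scatter. Nothing available here explains the size of any of these steps.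

The compounds shown leave open whether another aromatic ring with ring nitrogen, such as pyridin-2-yl, or a group with no aromatic ring at all, such as an acetyl or a plain methyl, would hold a read-out in this range on the same ring nitrogen. They also leave open whether these small differences at one tested concentration would carry over to full potency values.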